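The source may report more compounds than this note shows. Statements on the series, on what has been measured and on what is new or still open speak of the compounds shown alone.

Working notes on the series. Compound 2 `COc1ncc(-c2ccc3c(c2)N(c2ccc(F)cc2)C(=O)CO3)cc1NS(=O)(=O)c1ccc(F)cc1` stands lowest of the three numbers in a functional assay on A549 cells (Homo sapiens) for antiproliferative activity, read by MTT assay, with a stated time of 72 h (on this read-out higher numbers stand for weaker inhibition and lower numbers for stronger inhibition), where compound 2 gives 6500 nM. Among the compounds with values here, its nearest neighbour is compound 1 `O=C1COc2ccc(-c3cnc(Cl)c(NS(=O)(=O)c4ccc(F)cc4)c3)cc2N1c1ccc(F)cc1`, for which this assay gives 22300 nM; the step of a 3.4-fold lower number from compound 1 to compound 2 (0.54 log units; beyond the scatter) is the only single-point change measured so far. Compound 3 `O=C1COc2ccc(-c3cccc(NS(=O)(=O)c4ccc(F)cc4)c3)cc2N1c1ccc(Cl)cc1` gives 31600 nM in this assay and differs from the others in more than one place, so nothing can be said of any single step to it.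

Compound 4 `COc1cccc(N2C(=O)COc3ccc(-c4cnc(OC)c(NS(=O)(=O)c5ccc(F)cc5)c4)cc32)c1` is yet to be measured. The change is 3-methoxyphenyl in place of 4-fluorophenyl on an amide-type nitrogen in a ring. Within the data shown here, no measured step touches the group on the amide-type nitrogen in a ring: the step from compound 1 to compound 2 sits on the other aromatic ring, so it bears on this change only as a sign that single aromatic substituent swaps have moved the number modestly. With nothing direct to go on, no step beyond the scatter is expected in this assay, the estimated step being a 1.2-fold higher number from compound 2 to compound 4 (0.09 log units; within the scatter). Compound 4 is therefore estimated at 8000 nM, with a range from 3000 nM to 25000 nM.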

Compound 4, half-maximal inhibitory concentration: 11200 nM
Beside the measured number, compound 4's estimate is 1.4-fold (0.15 log units) below it; the range from low to high includes it.
By their numbers in this assay, from the lowest: compounds 2, 4, 1 and 3 (each within the scatter of the next, the first and the last beyond it).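

Within the data shown here, this is the first step read at the amide-type nitrogen in a ring: in this assay, putting 3-methoxyphenyl in place of 4-fluorophenyl gives a 1.7-fold higher number from compound 2 to compound 4 (0.24 log units; within the scatter). The swap adds one hydrogen-bond acceptor and one heavy atom to the group on that nitrogen, yet compound 2 and compound 4 cannot be told apart in this read-out, so this position tolerates this one exchange of substituted phenyl groups. Nothing at hand offers an explanation for this result.

The pair cannot separate the identity of the substituent from its place on the phenyl ring, as both differ at once. Also open, as far as these compounds go, is how this nitrogen responds to groups other than substituted phenyl, such as a short alkyl chain, a benzyl group or a phenyl carrying a carboxylic acid.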